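A few compounds are considered here, and "the series" means these few. Any claim that something is new, unique, unknown or untested is made for them only; others in the source may bear on it.

Of the compounds shown here, two of the same shared core have been tested in an ADME assay on HFF cells (Homo sapiens) for cytotoxicity, read by MTT assay, with a stated time of 72 h; on this read-out higher numbers stand for weaker inhibition and lower numbers for stronger inhibition. Compound 1, with the structure `CCCCCc1ccc(-c2cn(C[C@H](O)[C@H]3OC(=O)C(OCc4ccccc4)=C3OCc3ccccc3)nn2)cc1`, carries a 4-pentylphenyl group on the five-membered aromatic ring. In this assay compound 1 gives a value that is only a limit of the assay, > 100000 nM. Compound 2, with the structure `O=C1O[C@H]([C@@H](O)Cn2cc(-c3cc(F)cc(F)c3)nn2)C(OCc2ccccc2)=C1OCc1ccccc1`, carries a 3,5-difluorophenyl group in that place. In this assay compound 2 likewise gives only a limit, > 100000 nM. The step that the two limits leave unreadable from compound 1 to compound 2 therefore cannot be read, since both ends sit at the limit; the evidence on hand is the limit of > 100000 nM in this assay, at which 2 of the 2 values shown sit.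

Compound 3, with the structure `COc1ccc(-c2cn(C[C@H](O)[C@H]3OC(=O)C(OCc4ccccc4)=C3OCc3ccccc3)nn2)cc1`, is not yet measured. It differs from compound 2 in one place: 4-methoxyphenyl in place of 3,5-difluorophenyl on an aromatic carbon. Going by the values given here, because both measured compounds rest at the limit of > 100000 nM in this assay, at which 2 of the 2 values shown sit, no measured step gives a direction or size for this change, and a value at or beyond the limit is expected again for compound 3. The estimated step that the limit leaves unreadable from compound 2 to compound 3 is expected to be nothing beyond the scatter. Compound 3 is estimated at 150000 nM, within the range 50000 nM to 500000 nM.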

Compound 3, half-maximal inhibitory concentration: < 10 nM
Compound 3 ended at the assay's limit; the forecaster's own chance of this, stated with the estimate: 85%; at least 15000-fold (4.17 log units) between middle value and limit.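

The position on the five-membered aromatic ring is not indifferent to what it carries, which the two earlier compounds, resting at the same limit, could not show. In this assay, 4-methoxyphenyl in place of 3,5-difluorophenyl on this aromatic carbon gives an at least 10000-fold lower number from compound 2 to compound 3 (4.00 log units; beyond the scatter), and methoxy in place of pentyl on the phenyl ring gives an at least 10000-fold lower number from compound 1 to compound 3 (4.00 log units; beyond the scatter), so a single change of group here can carry the read-out from one end of its range to the other, and a group as small as methoxy does so where pentyl does not. Both steps run between limits of the assay rather than between numbers, so they give only a smallest possible size, and the one from compound 1 to compound 2 cannot be read at all: the limit of < 10 nM in this assay, at which 1 of the 3 values shown sits.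

The compounds shown leave open whether the effect depends on the methoxy group itself or would also appear with another group in its place, such as an amine, a carboxylic acid or a longer ether chain like ethoxy. They also leave open how strong compound 3 really is, since only a limit stands for it.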